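A Hydroxy Group Added to Compound 2

The source may hold more compounds than are shown below. What is called first, only, known or untested is meant among the compounds shown, and "the series" means these compounds.

The starting point is compound 2, `Oc1ccc2cc(-c3ccccc3)ccc2c1-c1cncnc1`, which was tested in an assay for binding affinity to 17-beta-hydroxysteroid dehydrogenase type 2 (Homo sapiens), read by scintillation counting, with a stated time of 10 min, tested at 1 uM; on this read-out higher numbers stand for more inhibition at the one concentration tested (going by the name of the read-out) and lower numbers for less inhibition. In this assay compound 2 gives only a limit, < 10%, which marks the edge of what the assay reports rather than a number. Among the measured compounds shown here, the only other compound measured in this assay is compound 1, `Oc1ccccc1-c1ccc2c(-c3cncnc3)cccc2c1`, which carries the same groups placed differently on the shared core. In this assay compound 1 likewise gives a limit, < 10%. For the measured compounds named here, both measured values therefore sit at the same edge, (the limit of < 10% in this assay, at which 2 of the 2 values shown sit), and no step between measured compounds can be read from them.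

The next compound is compound 3, `Oc1ccccc1-c1ccc2c(-c3cncnc3)c(O)ccc2c1`. It differs from compound 2 by hydroxy in place of hydrogen on an aromatic carbon. Going by the values given here, with no measured step to lean on, the expected change is small, and the step from compound 2 to compound 3 is expected to be a number at least 5 percentage points higher from compound 2 to compound 3 (that floor lies within the scatter), with a real chance that it stays within the scatter. On that basis compound 3 is estimated to give 15% in this assay, within a range from 0% to 45%.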

Compound 3, a percentage reported as inhibition, at one concentration (the size of the read-out at that concentration, not a potency): < 10%
Compound 3: a limit, no number (the forecaster's own chance of this, stated with the estimate: 50%); middle value at least 5 percentage points from the limit.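

In this assay compound 3 gives < 10%, which is a limit and not a number. Among the compounds shown here, no step from compound 1 or compound 2 to compound 3 can be read, because all the values sit at one edge: the limit of < 10% in this assay, at which 3 of the 3 values shown sit. The compounds shown leave open whether hydroxy in place of hydrogen on an aromatic carbon changes the inhibition at all.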